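Working notes: methoxy on compound 2

The source may report more compounds than this note shows. Statements on the series, on what has been measured and on what is new or still open speak of the compounds shown alone.

Measured in a functional assay for inhibition, with Homo sapiens as the target; a higher number here means a weaker inhibitor, a lower number a stronger inhibitor:
- compound 1 `CC(C)(C)Sc1c(CC(C)(C)C(=O)O)n(Cc2ccc(Cl)cc2)c2ccc(OCc3ccc4cccnc4n3)cc12`: 6 nM
- compound 2 `CC(C)(C)Sc1c(CC(C)(C)C(=O)O)n(Cc2ccc(Cl)cc2)c2ccc(OCc3nc4ccccc4s3)cc12`: 3 nM

Among the compounds with values here, compound 2 gives 3 nM, within the scatter of the only other measured number. Within the data shown here, the one measured step is a 2.0-fold lower number from compound 1 to compound 2 (0.30 log units; within the scatter). Compound 3 `COc1ccc2nc(COc3ccc4c(c3)c(SC(C)(C)C)c(CC(C)(C)C(=O)O)n4Cc3ccc(Cl)cc3)sc2c1` differs from compound 2 by methoxy in place of hydrogen on an aromatic carbon. Among the measured compounds shown here, that step replaces the whole group, so it bears only loosely on this smaller change, and no measured step tests methoxy directly. No shift beyond the scatter is expected. The expected step is a 1.3-fold higher number from compound 2 to compound 3 (0.12 log units; within the scatter). For compound 3 the estimate is 4 nM, with an expected range of 1.5 nM to 12 nM.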

Compound 3, half-maximal inhibitory concentration: 8 nM
The estimate for compound 3 lay 2.0-fold (0.30 log units) below the measured number, within the range that was stated.
By their numbers in this assay, from the lowest: compounds 2, 1 and 3 (each within the scatter of the next, the first and the last beyond it).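

In this assay adding methoxy to the benzothiazole gives a 2.7-fold higher number from compound 2 to compound 3 (0.43 log units; beyond the scatter), so this aromatic carbon responds to substitution, though only modestly. Set against the other bicyclic group, the 6-methoxy-1,3-benzothiazol-2-yl compound shows a 1.3-fold higher number from compound 1 to compound 3 (0.12 log units; within the scatter), leaving the two with no separation beyond the scatter. No evidence on the cause of this shift is at hand.

Methoxy is the only substituent shown on this carbon. Going by these compounds, whether a hydroxy group, a chlorine atom or an amine here would shift the number in the same direction, or further, remains open.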